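Chloro to cyano on a poorly retained compound

The source may report more compounds than this note shows. Statements on the series, on what has been measured and on what is new or still open speak of the compounds shown alone.

Among the compounds with values here, in an ADME assay on microsomes from liver (Mus musculus) for metabolic stability, read by LC-MS, with a stated time of 1 h, tested at 5 uM (a lower number here means that less of the compound is left, a higher number that more of the compound is left), compound 1 (`Cc1nc(-c2ccccc2)c(C(=O)N2CCN(c3cccc(Cl)c3)CC2)o1`) gives 2%, the lower of the two numbers so far, and compound 2 (`COc1cc(-c2nc(C)oc2C(=O)N2CCN(c3cccc(Cl)c3)CC2)ccc1O`) gives 72.5%. Compound 3 (`Cc1nc(-c2ccccc2)c(C(=O)N2CCN(c3cccc(C#N)c3)CC2)o1`) keeps the core of compound 1 but has cyano in place of chloro on an aromatic carbon, meta to a large group, so that 3-chlorophenyl becomes 3-cyanophenyl: cyano in place of chloro on an aromatic carbon. Within the data shown here, the only measured step, a number 70.5 percentage points higher from compound 1 to compound 2 (beyond the scatter), is large, but it exchanges phenyl for 4-hydroxy-3-methoxyphenyl and leaves the 3-chlorophenyl untouched. Among the measured compounds shown here, it therefore bears only loosely on this change, and no measured step covers this position. With compound 1 at 2%, a fall has little room, so a small rise in this assay, probably within the scatter, is expected. The expected change is a number 6 percentage points higher from compound 1 to compound 3 (within the scatter). For compound 3 the estimate is 8%, with an expected range of 1% to 25%.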

Compound 3, percent of the compound remaining: 1.6%
Estimate against measurement, compound 3: 6.4 percentage points above, and the stated range covers the measured number.
By their numbers in this assay, from the lowest: compounds 3 and 1 (each within the scatter of the next); then compound 2.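

In this assay, within the data shown here, 3-cyanophenyl in place of 3-chlorophenyl gives a number 0.4 percentage points lower from compound 1 to compound 3 (within the scatter), the first measured step at this position. Cyano in place of chloro on the core of compound 1 therefore leaves the number within the scatter, unlike the exchange of phenyl for 4-hydroxy-3-methoxyphenyl, which gives a number 70.5 percentage points higher from compound 1 to compound 2 (beyond the scatter) on the same core. Nothing measured here accounts for this result.

Since compound 1 already stands so low, the step does not show whether the same change would matter on a compound with more left, such as compound 2 at 72.5% in this assay. Also open, on these data alone, is whether another group on this aromatic carbon, such as an amine or a carboxylic acid, would move the number beyond the scatter.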